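Trifluoromethylsulfanyl in Place of Bromo: What to Expect

The compounds below may be only part of what the source reports. "The series", "measured", "known", "first", "only" and "open" are said of these compounds alone.

Of the compounds shown here, three built on one shared core have been measured in a functional assay on the whole organism with Rattus norvegicus as the target, at a dose of 20 mg/kg by the intraperitoneal route; on this read-out higher numbers stand for more inhibition at the one dose given (going by the name of the read-out) and lower numbers for less inhibition. Compound 1 `COc1ccc(Br)cc1-c1nc(N)nc(N)n1` gives 49%. Compound 2 `Nc1nc(N)nc(-c2cccc(Br)c2)n1` gives 96%, and compound 3 `Nc1nc(N)nc(-c2cc(Br)ccc2Cl)n1` gives 86%. Putting hydrogen in place of methoxy on an aromatic carbon brings a number 47 percentage points higher from compound 1 to compound 2 (beyond the scatter), and putting chloro in place of methoxy brings a number 37 percentage points higher from compound 1 to compound 3 (beyond the scatter), whereas chloro in place of hydrogen brings a number 10 percentage points lower from compound 2 to compound 3 (within the scatter). Compound 2 therefore stands highest of the three numbers, with compound 3 within the scatter of it and compound 1 far below.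

Compound 4 `Nc1nc(N)nc(-c2cccc(SC(F)(F)F)c2)n1` has not yet been measured. It differs from compound 2 in a single place: (trifluoromethyl)sulfanyl in place of bromo on an aromatic carbon. Every measured compound keeps its bromo group, and the three measured steps all alter a different aromatic carbon, so none of them bears directly on this exchange. The only firm anchor is the high level of compound 2. Without a measured step to lean on, a modest downward move is expected, a number 16 percentage points lower from compound 2 to compound 4 (beyond the scatter), which may well fall within the scatter. Compound 4 is estimated at 80%, with a range from 50% to 98%.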

Compound 4, a percentage reported as inhibition, in the whole organism at one dose (the size of the read-out at that dose, not a potency): 87%
The estimate for compound 4 lay 7 percentage points below the measured number, within the range that was stated.
By their numbers in this assay, from the lowest: compound 1; then compounds 3, 4 and 2 (each within the scatter of the next).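

Going by these compounds alone, every earlier step left the bromo group in place, so the exchange of bromo for (trifluoromethyl)sulfanyl is the first look at this position, and in this assay it gives a number 9 percentage points lower from compound 2 to compound 4 (within the scatter) in a single move. Among these compounds, then, a high reading at this position does not depend on bromo: it survives replacing 1 heavy atom with 5 heavy atoms, and a group with 0 hydrogen-bond acceptors with one that has 1 hydrogen-bond acceptor. Nothing at hand explains why the reading holds across this exchange.

The compounds shown do not reveal how much this position accepts, since an amine, a carboxylic acid or a longer chain such as butyl could keep the reading high or lose it. On these data alone, it also remains open whether (trifluoromethyl)sulfanyl would behave as it does here in the company of the methoxy group of compound 1 or the chloro group of compound 3, and whether compound 2 and compound 4 would still match at doses other than the single one used here.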